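This account rests on a few compounds, and the source may have more. Where it says the series, first, only, none or still open, it means among the compounds named here.

Measured so far in a functional assay on HCT-116 cells (Homo sapiens) for antiproliferative activity, read by MTT assay, with a stated time of 24 h; a higher number here means a weaker inhibitor, a lower number a stronger inhibitor:
Compound 1 `C#CCOc1ccc2c(=O)c(-c3cc(OC)c(OC)cc3OC)coc2c1` gives 8050 nM.
Compound 2 `COc1cc(OC)c(-c2coc3cc(OCc4ccc(Br)cc4)ccc3c2=O)cc1OC` gives 1980 nM.
Compound 3 `COc1cc(OC)c(-c2coc3cc(OCc4ccccc4C#N)ccc3c2=O)cc1OC` gives only > 10000 nM, a limit of the assay rather than a number (the limit of > 10000 nM in this assay, at which 1 of the 3 values shown sits).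

Compound 2 stands lowest of the two numbers, its nearest neighbour being compound 1, a 4.1-fold lower number from compound 1 to compound 2 (0.61 log units; beyond the scatter). Compound 4 `COc1cc(OC)c(-c2coc3cc(OCc4ccccc4Br)ccc3c2=O)cc1OC` differs from compound 2 by 2-bromophenyl in place of 4-bromophenyl on a saturated chain carbon bound to an oxygen on an aromatic ring. The step that bears on this is an at least 5.0-fold higher number from compound 2 to compound 3 (0.70 log units; beyond the scatter), where 4-bromophenyl was likewise exchanged, there for 2-cyanophenyl; an at least 1.2-fold higher number from compound 1 to compound 3 (0.09 log units; that floor lies within the scatter) points the same way. A modest rise in this assay is therefore expected for compound 4. Compound 4 is estimated at 6000 nM, within 2000 nM to 20000 nM. The expected step is a 3.0-fold higher number from compound 2 to compound 4 (0.48 log units; beyond the scatter).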

Compound 4, half-maximal inhibitory concentration: 4550 nM
Beside the measured number, compound 4's estimate is 1.3-fold (0.12 log units) above it; low and high end bracket the measured number.
By their numbers in this assay, from the lowest: compound 2; then compounds 4 and 1 (each within the scatter of the next). At a limit, above all of these: compound 3.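

The position of the bromine on the ring matters in this assay, even though the atoms stay the same: 2-bromophenyl in place of 4-bromophenyl gives a 2.3-fold higher number from compound 2 to compound 4 (0.36 log units; beyond the scatter). Bromo in place of cyano on an aromatic carbon gives an at least 2.1-fold lower number from compound 3 to compound 4 (0.34 log units; beyond the scatter), a step that rests on compound 3 having a limit rather than a number. 2-Bromophenyl in place of ethynyl gives a 1.8-fold lower number from compound 1 to compound 4 (0.25 log units; within the scatter), so this exchange cannot be told from scatter.

From the compounds shown here alone, only bromine has been compared at two ring positions here, so whether the same preference holds for other groups remains open. Going by these compounds, how a chloro group or an amine on this phenyl ring would read also remains open.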